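The compounds below may be only part of what the source reports. "The series", "measured", "known", "first", "only" and "open" are said of these compounds alone.

Going by the values given here, compound 2 `CCc1cc(C(C)=O)c(O)cc1OCCCC(C)(C)C(=O)O` stands at the lower of the two numbers measured so far: in an assay on isolated protein for binding affinity to leukotriene B4 receptor 1 (Homo sapiens), tested at 1 uM (a lower number here means less inhibition, a higher number more inhibition at the concentration tested (going by the name of the read-out)), compound 2 gives 43%, while compound 1 `CCc1cc(C(C)=O)c(O)cc1OCCCCCCC#N` gives 73%. Among the compounds with values here, the one measured step, a number 30 percentage points lower from compound 1 to compound 2 (beyond the scatter), exchanged the nitrile-bearing chain for the acid-bearing one and so speaks to the head group rather than to the chain length.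

Compound 3 `CCc1cc(C(C)=O)c(O)cc1OCCCCCC(C)(C)C(=O)O` differs from compound 2 in a single place: 3-carboxy-3-methylbutyl in place of 1-carboxy-1-methylethyl on a saturated chain carbon, three bonds along the chain from an oxygen on an aromatic ring. Within the data shown here, no measured pair shows what lengthening the chain that carries the acid does in this assay, so the step from compound 1 to compound 2 bears on it only loosely. With the longer chain of compound 3 lying closer in reach to the chain of compound 1, a small rise is expected, a number 12 percentage points higher from compound 2 to compound 3 (beyond the scatter), though one that may well stay within the scatter. Compound 3 is therefore estimated at 55% in this assay, with a range from 30% to 80%.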

Compound 3, a percentage reported as inhibition, at one concentration (the size of the read-out at that concentration, not a potency): 73%
Beside the measured number, compound 3's estimate is 18 percentage points below it; low and high end bracket the measured number.
By their numbers in this assay, from the lowest: compound 2; then compounds 1 and 3 (each within the scatter of the next).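

In this assay, going by these compounds alone, 3-carboxy-3-methylbutyl in place of 1-carboxy-1-methylethyl gives a number 30 percentage points higher from compound 2 to compound 3 (beyond the scatter), so at this position the length of the chain carrying the acid counts, which no earlier pair could show. Set against the nitrile-bearing chain, the longer acid-bearing chain shows no change at the digits printed from compound 1 to compound 3 (within the scatter), so the acid head group is compatible with the number reached by the nitrile and the earlier drop holds only for the shorter chain. Nothing at hand bears on what lies behind this result.

From the compounds shown here alone, whether a still longer chain would raise, hold or lower the number stays open. So does whether an amide or a tetrazole could stand in for the carboxylic acid on this chain, and whether the chain needs its two methyl groups.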